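Swapping a Ring Amide for a Small Amine

A few compounds are considered here, and "the series" means these few. Any claim that something is new, unique, unknown or untested is made for them only; others in the source may bear on it.

Compound 1 `CCCCCOC(=O)N1CCN(C(=O)[C@H](CCC(=O)O)NC(=O)c2cc(N3CCC(COC)CC3)nc(-c3ccccc3)n2)CC1`: in an ADME assay on microsomes from liver (Homo sapiens) for metabolic stability (a higher number here means that more of the compound is left, a lower number that less of the compound is left), compound 1 gives > 80%, a limit of the assay.
Compound 2 `CCCCCOC(=O)N1CCN(C(=O)[C@H](CCC(=O)O)NC(=O)c2cc(N3CCC(N4CCCC4)CC3)nc(-c3ccccc3)n2)CC1`: in this assay compound 2 gives > 80%, again a limit.
Compound 3 `CCCCCOC(=O)N1CCN(C(=O)[C@H](CCC(=O)O)NC(=O)c2cc(N3CCC(C(=O)N4CCCC4)CC3)nc(-c3ccccc3)n2)CC1`: in this assay compound 3 gives > 80%, also a limit.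

Compound 3 thus stands at the limit, because of the limit of > 80% in this assay, at which 3 of the 3 values shown sit; no measured value separates it from compounds 1 and 2. Compound 4 `CCCCCOC(=O)N1CCN(C(=O)[C@H](CCC(=O)O)NC(=O)c2cc(N3CCC(CNC)CC3)nc(-c3ccccc3)n2)CC1` carries (methylamino)methyl in place of (pyrrolidin-1-yl)carbonyl on a saturated ring carbon. Among the compounds with values here, the steps that bear on this change are a step that the two limits leave unreadable from compound 1 to compound 3 and a step that the two limits leave unreadable from compound 2 to compound 3, both hidden by the limit, as is a step that the two limits leave unreadable from compound 1 to compound 2. No readable step at this position has been seen. The step that the limit leaves unreadable from compound 3 to compound 4 is therefore expected to be small or none. Compound 4 is estimated at 85%, with a range from 65% to 98%.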

Compound 4, percent of the compound remaining: > 80%
Compound 4 ended at the assay's limit (the forecaster's own chance of this, stated with the estimate: 65%); the middle value lies beyond the limit too.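

No step can be read between compound 4 and compound 1, compound 2 or compound 3, because all four compounds sit at the same limit: the limit of > 80% in this assay, at which 4 of the 4 values shown sit. Going by these compounds, whether these groups on the saturated ring carbon differ at all in this assay stays open.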